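The source may hold more compounds than are shown below. What is called first, only, known or untested is meant among the compounds shown, and "the series" means these compounds.

In a functional assay on HeLa cells (Homo sapiens) for inhibition, read by trypan blue exclusion, with a stated time of 48 h (on this read-out higher numbers stand for weaker inhibition and lower numbers for stronger inhibition), compound 1 `CCCCCCC[C@@H](C/C=C/CCC(=O)N1CCCCC1)OC` gives > 100000 nM, which is a limit of the assay and not a number. Compound 2 `CCCCCCC[C@H](C/C=C/CCC(=O)N1CCCCC1)OC` gives > 100000 nM, which is also a limit. Among the compounds with values here, the only measured step, a step that the two limits leave unreadable from compound 1 to compound 2, therefore has no readable size, and it concerns (the fact that compounds 1 and 2 differ only in the configuration as drawn), not the group that changes next. Compound 3 `CCCCCCC[C@H](O)C/C=C/CCC(=O)N1CCCCC1` differs from compound 1 by hydrogen in place of methyl on an oxygen on a saturated carbon, or methoxy to hydroxy. Within the data shown here, no measured step shows what this change does, so any size expected here is uncertain. Compound 1 offers only a limit, so a readable value could only point towards stronger inhibition, and compound 3 may well remain at a limit. The expected step is an at least 1.4-fold lower number from compound 1 to compound 3 (0.15 log units; that floor lies within the scatter). Compound 3 is estimated at 70000 nM, within an expected range of 20000 nM to 200000 nM.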

Compound 3, half-maximal inhibitory concentration: > 100000 nM
Compound 3 gave a limit, no number; the forecaster's own chance of this, stated with the estimate: 60%; at least 1.4-fold (0.15 log units) between middle value and limit.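

Compound 1 and compound 3 both stop at a limit and give no number, so no size can be read for the change from methoxy to hydroxy: the limit of > 100000 nM in this assay, at which 3 of the 3 values shown sit. The compounds shown leave open whether this change affects inhibition of these cells at all.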